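This account rests on a few compounds, and the source may have more. Where it says the series, first, only, none or still open, it means among the compounds named here.

The two measured compounds share one core and a saturated two-carbon chain leading into an amine nitrogen in a ring. Compound 1, `C1=C(CCN2CCN(c3cccc4c3OCCO4)CC2)c2ccccc2C1`, carries that chain on a bicyclic group holding one double bond outside aromatic rings. In a functional assay on the whole organism for agonist activity, with Rattus norvegicus as the target (a lower number here means that less compound is needed, a higher number that more compound is needed for the effect), compound 1 gives only > 2.5 mg/kg, which is a limit of the assay and not a number. This is what the limit of > 2.5 mg/kg in this assay, at which 1 of the 2 values shown sits, records: a single bound, not a measured value. Compound 2, `COc1ccc2c(c1)C(CCN1CCN(c3cccc4c3OCCO4)CC1)C2`, carries the chain on a saturated bicyclic group bearing one further substituent. In this assay compound 2 gives 10 mg/kg. Compound 3, `c1ccc2c(c1)CCC2CCN1CCN(c2cccc3c2OCCO3)CC1`, has not yet been measured in this assay. Relative to compound 1 it differs by a group of 9 heavy atoms (9 carbon; one five-membered non-aromatic ring of carbon only, one six-membered aromatic ring of carbon only) in place of a group of 9 heavy atoms (9 carbon; one five-membered non-aromatic ring of carbon only, one six-membered aromatic ring of carbon only), on a saturated chain carbon, two bonds along the chain from an amine nitrogen in a ring. Going by the values given here, no measured pair shows a step of this kind, so its size is not known from the numbers. Because compound 1 shows only the limit > 2.5 mg/kg, no direction can be read from compound 1 itself. The change from compound 1 to compound 3 is expected to be a step that the limit leaves unreadable from compound 1 to compound 3, not clearly beyond the scatter. Because compound 2, the closest saturated relative, gives 10 mg/kg, compound 3 is estimated to give 10 mg/kg, within a range from 5 mg/kg to 20 mg/kg.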

Compound 3, minimum effective dose: > 40 mg/kg
Compound 3 gave a limit, no number; the forecaster's own chance of this, stated with the estimate: 20%; at least 4.0-fold (0.60 log units) between middle value and limit.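

Going by these compounds alone, compound 1 and compound 3 each give only a limit of the assay and not a number in this assay, so no step between them can be read. The compounds shown leave open whether replacing the group with a double bond outside aromatic rings by 2,3-dihydro-1H-inden-1-yl changes the minimum effective dose, and in which direction.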